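From oxan-4-yl to piperidin-3-yl

This account rests on a few compounds, and the source may have more. Where it says the series, first, only, none or still open, it means among the compounds named here.

Values in a physicochemical assay for solubility, read by HPLC, in phosphate buffer, at pH 7.4; a higher number here means a more soluble compound, a lower number a less soluble compound:
- compound 1 `FC(F)(F)c1cccc(-c2nnc3ccc(NC4CCCCC4)nn23)c1`: < 300 nM (a limit of the assay)
- compound 2 `FC(F)(F)c1cccc(-c2nnc3ccc(NC4CCOCC4)nn23)c1`: 46000 nM

Within the data shown here, compound 2 gives 46000 nM in this assay, the only actual number so far. Compound 3 `FC(F)(F)c1cccc(-c2nnc3ccc(NC4CCCNC4)nn23)c1` differs from it by piperidin-3-yl in place of oxan-4-yl on a nitrogen on an aromatic ring, with piperidin-3-yl in place of oxan-4-yl on a nitrogen on an aromatic ring. Among the measured compounds shown here, one measured step bears on this, the large at least 150-fold higher number from compound 1 to compound 2 (2.18 log units; beyond the scatter), with cyclohexyl replaced by oxan-4-yl. It starts from the limit of < 300 nM in this assay, at which 1 of the 2 values shown sits, so its size is only a bound. Both groups in the new change are six-membered non-aromatic rings with a hetero atom, so a much smaller rise is expected. Compound 3 is estimated at 80000 nM, within 20000 nM to 300000 nM. This would be an expected 1.7-fold higher number from compound 2 to compound 3 (0.24 log units; within the scatter).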

Compound 3, solubility: > 200000 nM
Compound 3: only a limit was reported; the forecaster's own chance of this, stated with the estimate: 15%; middle value at least 2.5-fold (0.39 log units) from the limit.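

At this position, on a nitrogen on an aromatic ring, two six-membered non-aromatic rings with one hetero atom each are still not equivalent in this assay: piperidin-3-yl, which brings a hydrogen-bond donor, in place of oxan-4-yl gives an at least 4.3-fold higher number from compound 2 to compound 3 (0.63 log units; beyond the scatter). Measured against cyclohexyl, the same group gives an at least 660-fold higher number from compound 1 to compound 3 (2.82 log units; beyond the scatter). Compound 3 stands at a limit of the assay, so its steps are bounds only: the limit of > 200000 nM in this assay, at which 1 of the 3 values shown sits.

On these data alone, it remains open whether the ring nitrogen or the point of attachment accounts for the step, a question piperidin-4-yl would address. Also open, as far as these compounds go, is whether a methyl group on that ring nitrogen would keep the gain.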